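Swapping Methoxy for Chloro on an Aromatic Carbon

The source may report more compounds than this note shows. Statements on the series, on what has been measured and on what is new or still open speak of the compounds shown alone.

Compound 1 `COc1ccc(N2CCN(CC(=O)N3CCN(c4nnc(-c5ccccc5)c(-c5ccccc5)n4)CC3)CC2)cc1` and compound 2 `O=C(CN1CCN(c2ccc(Cl)cc2)CC1)N1CCN(c2nnc(-c3ccccc3)c(-c3ccccc3)n2)CC1` share one core and differ in a single place: chloro in place of methoxy on an aromatic carbon. In a functional assay on MCF7 cells (Homo sapiens) for cytotoxicity, read by MTT assay, with a stated time of 24 h (on this read-out higher numbers stand for weaker inhibition and lower numbers for stronger inhibition), compound 1 gives only a limit, > 910000 nM. In this assay compound 2 gives 56300 nM. The step is an at least 16-fold lower number from compound 1 to compound 2 (1.20 log units; beyond the scatter). Compound 3 `COc1ccc(-c2nnc(N3CCN(C(=O)CN4CCN(c5ccccc5OC)CC4)CC3)nc2-c2ccc(OC)cc2)cc1` is built on a different core; the difference between the two cores is not broken down here. In this assay compound 3 gives only a limit, > 821000 nM. Compound 4 `COc1ccc(-c2nnc(N3CCN(C(=O)CN4CCN(c5ccccc5Cl)CC4)CC3)nc2-c2ccc(OC)cc2)cc1` has not been measured and differs from compound 3 in one place: chloro in place of methoxy on an aromatic carbon. Here the place is ortho to a large group rather than para to a large group, so this is the same kind of change, not the same one. Resting on an at least 16-fold lower number from compound 1 to compound 2 (1.20 log units; beyond the scatter), the step is expected to be an at least 4.1-fold lower number from compound 3 to compound 4 (0.61 log units; beyond the scatter). Compound 4 is estimated at 200000 nM.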

Compound 4, half-maximal inhibitory concentration: > 814000 nM
Compound 4 ended at the assay's limit; the forecaster's own chance of this, stated with the estimate: 40%; middle value at least 4.0-fold (0.60 log units) from the limit.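

Compound 3 and compound 4 both give only limits in this assay, and the step between them cannot be read. The compounds shown leave open whether going from 2-methoxyphenyl to 2-chlorophenyl on the core of compound 3 changes the read-out at all.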